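Moving the Fluorine: 4-Fluorobenzyl to 2-Fluorobenzyl

This account rests on a few compounds, and the source may have more. Where it says the series, first, only, none or still open, it means among the compounds named here.

Compound 1 `COc1ccc(/C=C2\CN(C(=S)SCc3cn(Cc4ccc(F)cc4)nn3)C/C(=C\c3ccc(OC)cc3)C2=O)cc1`: 74600 nM
Compound 2 `COc1ccc(/C=C2\CN(Cc3cn(Cc4ccc(F)cc4)nn3)C/C(=C\c3ccc(OC)cc3)C2=O)cc1`: 59400 nM

Both numbers come from a functional assay on DU-145 cells (Homo sapiens) for cytotoxicity, read by MTT assay, with a stated time of 24 h; on this read-out lower numbers stand for stronger inhibition and higher numbers for weaker inhibition. Going by the values given here, compound 2 stands level with compound 1, the only other compound measured, since their two numbers lie within the usual scatter of each other.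

The next compound, compound 3 `COc1ccc(/C=C2\CN(Cc3cn(Cc4ccccc4F)nn3)C/C(=C\c3ccc(OC)cc3)C2=O)cc1`, has the same atoms as compound 2, joined differently: 2-fluorophenyl in place of 4-fluorophenyl on a saturated chain carbon bound to an aromatic nitrogen. Here 2-fluorophenyl sits in place of 4-fluorophenyl on a saturated chain carbon bound to an aromatic nitrogen. Among the compounds with values here, no measured pair shows what a change of this kind does, so the closest guide is compound 2 at 59400 nM. The estimated 1.2-fold lower number from compound 2 to compound 3 (0.07 log units; within the scatter) is expected to stay within the scatter, with no firm direction. Compound 3 is estimated at 50000 nM, with an expected range from 22000 nM to 100000 nM.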

Compound 3, half-maximal inhibitory concentration: 32600 nM
For compound 3 the middle estimate is 1.5-fold (0.19 log units) above the measured one; the range from low to high includes it.
By their numbers in this assay, from the lowest: compounds 3, 2 and 1 (each within the scatter of the next, the first and the last beyond it).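

Going by these compounds alone, this is the first measured step at the fluorine of the benzyl group. In this assay, 2-fluorophenyl in place of 4-fluorophenyl on a saturated chain carbon bound to an aromatic nitrogen gives a 1.8-fold lower number from compound 2 to compound 3 (0.26 log units; within the scatter) and so, with the same atoms joined differently, the two compounds cannot be told apart on this read-out, and moving the fluorine shows no firm effect in this pair. No measurement at hand offers an explanation for this result.

On these data alone, whether a plain benzyl group, a 2-chlorobenzyl group or a longer chain on the same aromatic nitrogen would shift the number beyond the scatter stays open. Also open, as far as these compounds go, is whether the same change would read alike with the linker of compound 1 in place.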